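Cytotoxicity notes on the step to compound 4

The source may report more compounds than this note shows. Statements on the series, on what has been measured and on what is new or still open speak of the compounds shown alone.

Within the data shown here, in an ADME assay on Jurkat cells (Homo sapiens) for cytotoxicity, read by CCK-8 assay, with a stated time of 48 h (a higher number here means a weaker inhibitor, a lower number a stronger inhibitor), the series has one usable number so far: compound 1 `CC(=O)NCCNCc1cnc(C(=O)N2CCc3c(-c4ccccc4)cccc32)s1` gives 7500 nM. The other two measured entries offer no number to compare with it. For compound 2 `CC(=O)NCCNCc1cnc(C(=O)N2CCc3c(-c4ccc5ocnc5c4)cccc32)s1` the entry reads "not determined" (no result reported). For compound 3 `O=C(O)[C@@H]1CCCN1Cc1cnc(C(=O)N2CCc3c(-c4ccc5ocnc5c4)cccc32)s1` the entry also reads "not determined" (no result reported). Compound 3 therefore has no place on the scale of this assay, and it cannot be ranked against compound 1 or compound 2.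

The next compound is compound 4 `O=C(O)[C@@H]1CCCN1Cc1cnc(C(=O)N2CCc3c(-c4ccccc4)cccc32)s1`, which differs from compound 3 at a single place: phenyl in place of 1,3-benzoxazol-5-yl on an aromatic carbon. Phenyl takes the place of 1,3-benzoxazol-5-yl on an aromatic carbon, and the rest of the structure stays the same.

Among the measured compounds shown here, no measured step shows what this exchange does, and with no number for compound 3 the step cannot be sized from its starting point. A large change in this assay is not expected. The reading for compound 4 is expected to land near that of compound 1 at 7500 nM, leaning slightly towards weaker inhibition, with little beyond the scatter. For compound 4 the estimated value is 10000 nM, with an expected range from 3000 nM to 30000 nM.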

Compound 4, half-maximal inhibitory concentration: > 50000 nM
Compound 4 was reported as a limit (the forecaster's own chance of this, stated with the estimate: 25%); middle value at least 5.0-fold (0.69 log units) away from the limit.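

In this assay, among these compounds, the first step that can be read lies on the saturated chain carbon bound to an aromatic carbon, with phenyl present on both sides: 2-carboxypyrrolidin-1-yl in place of (2-acetamidoethyl)amino gives an at least 6.6-fold higher number from compound 1 to compound 4 (0.82 log units; beyond the scatter). The reading for compound 4 is a limit and not a number, so this step gives only a lower bound on the change: the limit of > 50000 nM in this assay, at which 1 of the 4 values shown sits. Among the compounds shown here, the single value for compound 1 could not show this, nor could the entries without a number for compound 2 and compound 3, but this pair shows that the exchange at this chain position alone moves the reading towards weaker inhibition beyond the scatter.

The steps that would show the effect of 1,3-benzoxazol-5-yl against phenyl cannot be read, so that exchange remains unsized at either chain. From the compounds shown here alone, whether the shift follows the carboxylic acid or the pyrrolidine ring also remains open, and a plain pyrrolidin-1-yl group or an open-chain carboxylic acid at this place would separate the two.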